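Swapping an amide tail for an amine on the piperazine

The compounds below may be only part of what the source reports. "The series", "measured", "known", "first", "only" and "open" are said of these compounds alone.

Compound 2 `NC(=O)CN1CCN(c2nc(-c3cccnc3)nc3c2CN(Cc2ccccc2)CC3)CC1` was tested in an assay on A549 cells with Cystic fibrosis transmembrane conductance regulator variant F508del (Homo sapiens) as the target, read by fluorescence, with a stated time of 25 min (on this read-out higher numbers stand for larger maximal responses and lower numbers for smaller maximal responses), and gave "not active" (no number reported), so no number describes where it stands; it simply shows no response beyond what the assay counts as inactive. A related compound 1 `CN(C)CCN1CCN(c2nc(-c3ccccn3)nc3c2CN(Cc2ccccc2)CC3)CC1` carries a 4-(2-(dimethylamino)ethyl)piperazin-1-yl group and differs from compound 2 also elsewhere in its core; in this assay compound 1 reaches 57%. Compound 3 `CN(C)CCN1CCN(c2nc(-c3cccnc3)nc3c2CN(Cc2ccccc2)CC3)CC1` keeps the core of compound 2 and changes only the tail on the piperazine: (dimethylamino)methyl in place of carbamoyl on a saturated chain carbon bound to an amine nitrogen in a ring. Within the data shown here, with no measured pair that shares exactly this change, the expected size of the step is uncertain, but the direction is upward, since compound 2 starts from no response and compound 1 shows that the entering group is compatible with a clear response. The maximal response of compound 3 is therefore expected at about 35%, estimated within a range from 10% to 60%.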

Compound 3, largest response reached (Emax), in percent of the reference or control that the assay uses: "not active" (no number reported)
No number was reported for compound 3; no gap can be computed for the estimate.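

In this assay both compound 2 and compound 3 are reported as not active with no number, so no step can be read between them. No supporting evidence bears on this result. What the compounds shown leave open is whether swapping carbamoylmethyl for 2-(dimethylamino)ethyl changes the response at all.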